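Adding a Second Chloro Group to Compound 2

The compounds below may be only part of what the source reports. "The series", "measured", "known", "first", "only" and "open" are said of these compounds alone.

Values measured in a functional assay on the whole organism for inhibition, with Rattus norvegicus as the target (a lower number here means that less compound is needed, a higher number that more compound is needed for the effect), are as follows.

- Compound 1 `CCCCc1ncc(/C=C(\Cc2cccs2)C(=O)O)n1Cc1ccc(C(=O)O)cc1Cl` gives 0.06 mg/kg
- Compound 2 `CCCCc1ncc(/C=C(\Cc2cccs2)C(=O)O)n1Cc1ccc(C(=O)O)c(Cl)c1` gives 0.12 mg/kg

Within the data shown here, compound 2 stands within the scatter of compound 1, the only other measured compound, so the two numbers cannot be ranked. Compound 3 `CCCCc1ncc(/C=C(\Cc2cccs2)C(=O)O)n1Cc1ccc(C(=O)O)c(Cl)c1Cl` keeps the shared core of compound 2 and changes it in one place (chloro in place of hydrogen on an aromatic carbon), with chloro in place of hydrogen on an aromatic carbon, ortho to a chloro group and meta to a carboxy group.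

Among the measured compounds shown here, no measured step adds a chloro group, so the evidence is indirect. For the measured compounds named here, the one step that bears on the change exchanges 4-carboxy-2-chlorophenyl for 4-carboxy-3-chlorophenyl (a 2.0-fold higher number from compound 1 to compound 2 (0.30 log units; within the scatter)). It shows that the two singly chlorinated compounds do not separate in this assay, but it says nothing direct about carrying a second chloro group. No shift beyond the scatter is therefore expected, and the estimated step is small (a 1.3-fold lower number from compound 2 to compound 3 (0.12 log units; within the scatter)). The expected value for compound 3 is 0.09 mg/kg (estimated range 0.03 mg/kg to 0.3 mg/kg).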

Compound 3, dose for 50% inhibition: 0.04 mg/kg
Compound 3: middle estimate off by 2.3-fold (0.35 log units), on the high side; the measured number falls inside the stated range.
By their numbers in this assay, from the lowest: compounds 3, 1 and 2 (each within the scatter of the next, the first and the last beyond it).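

In this assay, among these compounds, chloro in place of hydrogen on the aromatic carbon ortho to a chloro group and meta to a carboxy group gives a modest step, a 3.0-fold lower number from compound 2 to compound 3 (0.48 log units; beyond the scatter), and this is the first step to lie beyond the scatter. The position therefore accepts a second chloro group without loss in this whole-organism measure, and the number moves measurably when the change is read against the compound that already carries the chloro group at the ortho position. The picture is different from the other singly chlorinated compound, where the step, a 1.5-fold lower number from compound 1 to compound 3 (0.18 log units; within the scatter), stays within the scatter and the two numbers cannot be ranked, so the benefit of the second chloro group is visible against only one of the two parents, and no measurement here bears on the reason for the shift.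

The compounds shown leave open whether a fluoro or a methyl group on the same aromatic carbon would give a step of similar size. They also leave open whether chloro at this position would move the number without the existing ortho chloro group.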